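From ethynyl to 1-(2-methylphenyl)-1H-1,2,3-triazol-4-yl: compound 4

The source may hold more compounds than are shown below. What is called first, only, known or untested is meant among the compounds shown, and "the series" means these compounds.

Going by the values given here, compound 3 `C#CCOC(=O)/C(C)=C/CC/C(C)=C/CC/C(C)=C/CC[C@@H]1[C@@]2(C)CCC(=O)C(C)(C)[C@H]2CC[C@@]1(C)O` gives the only true number so far in a functional assay on MDA-MB-231 cells (Homo sapiens) for antiproliferative activity, read by MTT assay, with a stated time of 48 h; a lower number here means a stronger inhibitor, a higher number a weaker inhibitor (114000 nM). Compound 1 `COc1ccccc1-n1cc(COC(=O)/C(C)=C/CC/C(C)=C/CC/C(C)=C/CC[C@@H]2[C@@]3(C)CCC(=O)C(C)(C)[C@H]3CC[C@@]2(C)O)nn1` reports only a limit (> 150000 nM). Compound 2 `C/C(=C\CC/C(C)=C/CC[C@@H]1[C@@]2(C)CCC(=O)C(C)(C)[C@H]2CC[C@@]1(C)O)CC/C=C(\C)C(=O)OCc1cn(-c2ccc(C(F)(F)F)cc2)nn1` also reports only a limit (> 150000 nM).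

Compound 4 `C/C(=C\CC/C(C)=C/CC[C@@H]1[C@@]2(C)CCC(=O)C(C)(C)[C@H]2CC[C@@]1(C)O)CC/C=C(\C)C(=O)OCc1cn(-c2ccccc2C)nn1` departs from compound 3 at one place (1-(2-methylphenyl)-1H-1,2,3-triazol-4-yl in place of ethynyl on a saturated chain carbon bound to an oxygen next to a carbonyl group): 1-(2-methylphenyl)-1H-1,2,3-triazol-4-yl in place of ethynyl on a saturated chain carbon bound to an oxygen next to a carbonyl group.

Among the compounds with values here, the only measured step (a step that the two limits leave unreadable from compound 1 to compound 2) puts 4-(trifluoromethyl)phenyl in place of 2-methoxyphenyl on an aromatic nitrogen, and its size cannot be read. Within the data shown here, no measured step covers the loss of ethynyl itself. The closest guide is the shared limit (the limit of > 150000 nM in this assay, at which 2 of the 3 values shown sit), reached by compound 1 and compound 2, which both carry a substituted phenyl on a triazole, as compound 4 does. In this assay a modest move toward weaker inhibition is therefore expected, and a reading that is only a limit is somewhat more likely than a number. The expected change (a 1.4-fold higher number from compound 3 to compound 4 (0.15 log units; within the scatter)) is small and may stay within the usual scatter. The estimated value for compound 4 is 160000 nM, with an expected range from 70000 nM to 300000 nM.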

Compound 4, half-maximal inhibitory concentration: > 150000 nM
Compound 4: a limit, no number (the forecaster's own chance of this, stated with the estimate: 60%); the middle value does not contradict the limit.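

In this assay, going by these compounds alone, exchanging ethynyl for 1-(2-methylphenyl)-1H-1,2,3-triazol-4-yl gives an at least 1.3-fold higher number from compound 3 to compound 4 (0.11 log units; that floor lies within the scatter), the first step that reaches from the ethynyl ester to a phenyl triazole. Only a floor is known for this step, and it does not establish a real loss of activity on installing the triazole at this saturated chain carbon, although no true number returns with the larger group. With 2-methylphenyl, the series now has a third substituted phenyl on the triazole that ends at the same limit, alongside 2-methoxyphenyl and 4-(trifluoromethyl)phenyl: the limit of > 150000 nM in this assay, at which 3 of the 4 values shown sit.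

On these data alone, the steps among compound 1, compound 2 and compound 4 join limits and cannot be read, so no ranking of these phenyl substituents is available, and the true size of the step to the triazole also stays open. Also open, as far as these compounds go, is whether an amine or a carboxylic acid on the phenyl, or a benzyl in place of the phenyl on the aromatic nitrogen, would bring a triazole ester of this series to a true number.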